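A few compounds are considered here, and "the series" means these few. Any claim that something is new, unique, unknown or untested is made for them only; others in the source may bear on it.

Notes on the series. In a functional assay on cells for agonist activity at melatonin receptor type 1B (Homo sapiens), read by GTPgammaS binding, with a stated time of 30 min (a higher number here means a larger maximal response, a lower number a smaller maximal response), compound 2 `CC(=O)NCCN(C)c1cccc(OCCCCCCN)c1` gives 0.08, the lowest of the three numbers; compound 1 `CC(=O)NCCN(C)c1cccc(OCCCCNC(=O)Oc2cccc(-c3ccccc3)c2)c1` gives 0.39 and compound 3 `CC(=O)NCCN(C)c1cccc(OCCCCCCOc2cccc(O)c2)c1` gives 0.57. Going by the values given here, the one measured step in this assay, a number 0.49 higher from compound 2 to compound 3 (beyond the scatter), concerns a different change at the chain end, not chain length. Compound 4 `CC(=O)NCCN(C)c1cccc(OCCCCN)c1` is related to compound 2 by amino in place of 2-aminoethyl on a saturated chain carbon, four bonds along the chain from an oxygen on an aromatic ring. Among the compounds with values here, no measured step shortens the chain while keeping the amino, so nothing bears directly on this move; the only rise seen came with the 3-hydroxyphenoxy of compound 3. Compound 4 is expected to stay close to compound 2. The step a number 0.020 higher from compound 2 to compound 4 (within the scatter) is expected to lie within the scatter. For compound 4 the estimate in this assay is 0.1, with a range from 0 to 0.25.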

Compound 4, intrinsic activity: the largest response reached, as a fraction of the reference agonist's: 0.35
Compound 4: the middle estimate sits 0.25 below what was measured; measured number outside the range, above it.
By their numbers in this assay, from the lowest: compound 2; then compounds 4 and 1 (each within the scatter of the next); then compound 3.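

In this assay, amino in place of 2-aminoethyl, four bonds along the chain from an oxygen on an aromatic ring, gives a number 0.27 higher from compound 2 to compound 4 (beyond the scatter). The maximal response therefore depends on the length of the chain even with the terminal amino kept, whereas the earlier step changed the chain end itself. Nothing available accounts for this rise.

As far as these compounds go, whether the response follows chain length steadily stays open, and a 3-aminopropyl group at this place would test that. Also open, from the compounds shown here alone, is whether a carboxylic acid in place of the amino on the shorter chain keeps this response.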